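The compounds below may be only part of what the source reports. "The series", "measured", "known", "first", "only" and "open" are said of these compounds alone.

Measured so far in an assay on HEK293 cells for positive allosteric modulation of metabotropic glutamate receptor 5 (Homo sapiens), read by FLIPR; on this read-out higher numbers stand for an effect only at larger amounts of compound and lower numbers for an effect already at smaller amounts:

compound 1, `Cc1cccc(-c2noc(C3CN(S(=O)(=O)c4ccc(Cl)cc4)C3)n2)c1`, > 10000 nM
compound 2, `O=C(c1ccccc1F)N1CC[C@H]1c1nc(-c2cccc(F)c2)no1`, > 10000 nM
compound 3, `O=C(C1CCCCC1)N1CC(c2nc(-c3cccc(F)c3)no2)C1`, 1000 nM

The three compounds share a core in which an azetidine carries an oxadiazole bearing a substituted phenyl ring. In this assay compound 1 reaches only a limit, > 10000 nM, and not a number. Compound 2 likewise reaches only a limit, > 10000 nM. Compound 3, the cyclohexyl amide with a 3-fluorophenyl, gives 1000 nM in this assay. Compound 1 therefore stands at the limit of > 10000 nM in this assay, at which 2 of the 3 values shown sit; its place on the scale is known only as that limit, and nothing in the data says how far past it the compound lies.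

Compound 4, `O=S(=O)(c1ccc(Cl)cc1)N1CC(c2nc(-c3cccc(Cl)c3)no2)C1`, has not yet been measured in this assay. It differs from compound 1 in one place: chloro in place of methyl on an aromatic carbon. For the measured compounds named here, no two measured compounds differ from one another in a single place, so no measured step tells how this assay answers to such a change. Given that compound 1 gives only > 10000 nM, compound 4 is expected to sit near the limit as well, with a step of a number no higher from compound 1 to compound 4 (the limit leaves the size open) expected to stay within the scatter. Compound 4 is thus estimated at 10000 nM, most likely between 3000 nM and 30000 nM, with a fair chance that only a limit is reported.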

Compound 4, half-maximal effective concentration: > 10000 nM
Compound 4: only a limit was reported; the forecaster's own chance of this, stated with the estimate: 60%; the middle value lies on the limit itself.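

In this assay, compound 4, like compound 1, is reported only as a limit, so no step can be read between the two compounds. Compound 4 joins the values held at that limit: the limit of > 10000 nM in this assay, at which 3 of the 4 values shown sit.

The compounds shown leave open how far past the limit either compound lies, and whether chloro in place of methyl changes the read-out at all.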